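Piperidine Replaces Triazole on the Propyl Chain

A few compounds are considered here, and "the series" means these few. Any claim that something is new, unique, unknown or untested is made for them only; others in the source may bear on it.

Measured compounds:
Compound 1, `Cn1cc(C2=C(c3nn(CCCn4cncn4)c4ncccc34)C(=O)NC2=O)c2ccccc21`, gives only a limit of the assay: > 100000 nM.
Compound 2, `Cn1cc(C2=C(c3nn(CCCn4cccc4)c4ncccc34)C(=O)NC2=O)c2ccccc21`, gives only a limit of the assay: > 100000 nM.
Compound 3, `Cn1cc(C2=C(c3nn(CCCN4CCCCC4)c4ncccc34)C(=O)N(c3cccc4ccccc34)C2=O)c2ccccc21`, gives 1830 nM.

In a functional assay on ECa-109 cells (Homo sapiens) for antiproliferative activity, read by MTT assay, with a stated time of 48 h (on this read-out lower numbers stand for stronger inhibition and higher numbers for weaker inhibition), compound 1 stands at a limit, not a number. Compound 2 stands at the same limit, so a step that the two limits leave unreadable from compound 1 to compound 2 cannot be sized; the limit of > 100000 nM in this assay, at which 2 of the 3 values shown sit, holds two of the three values. Compound 4, `Cn1cc(C2=C(c3nn(CCCN4CCCCC4)c4ncccc34)C(=O)NC2=O)c2ccccc21`, arises from compound 1 through (piperidin-1-yl in place of 1H-1,2,4-triazol-1-yl on a saturated chain carbon, three bonds along the chain from an aromatic nitrogen). Within the data shown here, no measured step covers this exchange by itself. Compound 3 carries the same piperidin-1-yl chain and returns a number, though it also differs elsewhere from compound 4. Compound 4 is therefore expected to come in at 20000 nM, between 3000 nM and 100000 nM. The expected step is an at least 5.0-fold lower number from compound 1 to compound 4 (0.69 log units; beyond the scatter).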

Compound 4, half-maximal inhibitory concentration: 42300 nM
Estimate against measurement, compound 4: 2.1-fold (0.33 log units) below; the range from low to high includes it.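

In this assay, among these compounds, piperidin-1-yl on the propyl chain gives the first number for a compound carrying the amide hydrogen, with an at least 2.3-fold lower number from compound 1 to compound 4 (0.37 log units; beyond the scatter) and an at least 2.3-fold lower number from compound 2 to compound 4 (0.37 log units; beyond the scatter). The end group of this chain therefore matters, even though neither earlier compound gave a number. With that chain held fixed, the other change, hydrogen in place of naphthalen-1-yl on the amide-type nitrogen, gives a 23-fold higher number from compound 3 to compound 4 (1.36 log units; beyond the scatter).

The step between the triazole and pyrrole compounds cannot be read, and the full size of the two chain steps stays open: the limit of > 100000 nM in this assay, at which 2 of the 4 values shown sit.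

From the compounds shown here alone, whether morpholin-4-yl on the propyl chain, or phenyl on the amide-type nitrogen, would give a lower number also remains open.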